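Amide aryl variation on the shared core

The source may hold more compounds than are shown below. What is called first, only, known or untested is meant among the compounds shown, and "the series" means these compounds.

Three amides of the shared core have been measured in a functional assay on MDA-MB-231 cells (Homo sapiens) for cytotoxicity, read by MTT assay; on this read-out higher numbers stand for weaker inhibition and lower numbers for stronger inhibition. Compound 1 `CCn1cc(C(=O)Nc2ccccc2N)c(=O)c2cc(F)c(N3CCNC(C)C3)c(F)c21` gives 9500 nM. Compound 2 `CCn1cc(C(=O)Nc2ccc(Cl)cn2)c(=O)c2cc(F)c(N3CCNC(C)C3)c(F)c21` gives 4800 nM, and compound 3 `CCn1cc(C(=O)Nc2cccc([N+](=O)[O-])c2)c(=O)c2cc(F)c(N3CCNC(C)C3)c(F)c21` gives 3250 nM. Among these three, compound 3 carries the lowest number; the step of a 2.9-fold lower number from compound 1 to compound 3 (0.47 log units; beyond the scatter) is beyond the scatter, whereas a 1.5-fold lower number from compound 2 to compound 3 (0.17 log units; within the scatter) and a 2.0-fold lower number from compound 1 to compound 2 (0.30 log units; within the scatter) are not, so compound 3 and compound 2 cannot be told apart on these numbers.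

Compound 4 `CCn1cc(C(=O)Nc2ccc(C)c([N+](=O)[O-])c2)c(=O)c2cc(F)c(N3CCNC(C)C3)c(F)c21` differs from compound 3 by methyl in place of hydrogen on an aromatic carbon. Going by the values given here, none of the measured steps adds a small group to a retained aryl ring; each exchanges the whole aryl group on the amide-type nitrogen, and even those exchanges moved this assay by at most a modest amount, as a 2.9-fold lower number from compound 1 to compound 3 (0.47 log units; beyond the scatter) shows. Among the compounds with values here, no measured step therefore bears directly on a methyl entering this ring, and the series gives no direction for it. The expectation is a step of a 1.1-fold lower number from compound 3 to compound 4 (0.03 log units; within the scatter) that stays within the scatter. Compound 4 is accordingly expected to give about 3000 nM in this assay, with a range from 1200 nM to 8000 nM.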

Compound 4, half-maximal inhibitory concentration: 4200 nM
Estimate against measurement, compound 4: 1.4-fold (0.15 log units) below; low and high end bracket the measured number.
By their numbers in this assay, from the lowest: compounds 3, 4, 2 and 1 (each within the scatter of the next, the first and the last beyond it).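

In this assay, going by these compounds alone, methyl in place of hydrogen on an aromatic carbon, ortho to a nitro group and para to a large group, is the first change made on a retained aryl ring, and it gives a 1.3-fold higher number from compound 3 to compound 4 (0.11 log units; within the scatter), so compound 3 and compound 4 cannot be told apart. The 4-methyl-3-nitrophenyl amide also cannot be told apart from the 5-chloropyridin-2-yl amide, with a 1.1-fold lower number from compound 2 to compound 4 (0.06 log units; within the scatter), yet it remains separated from the 2-aminophenyl amide by a 2.3-fold lower number from compound 1 to compound 4 (0.35 log units; beyond the scatter), so adding the methyl leaves the one separation seen with the 3-nitrophenyl amide in place. Nothing accompanying these numbers speaks to what lies behind them.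

The compounds shown leave open whether a primary amine, a carboxylic acid or a longer chain such as propyl on this same aromatic carbon would move the number beyond the scatter, as methyl does not. They also leave open whether methyl gives an equally small step on a phenyl ring that carries no nitro group.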